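Swapping Nitro for Hydroxy on an Aromatic Carbon

The compounds below may be only part of what the source reports. "The series", "measured", "known", "first", "only" and "open" are said of these compounds alone.

Compound 1 `COc1ccc(N(C)c2ccnc(Cl)n2)cc1F` gives 914 nM
Compound 2 `COc1ccc(N(C)c2ccnc(Cl)n2)cc1[N+](=O)[O-]` gives 4700 nM
Compound 3 `COc1ccc(N(C)c2ccnc(Cl)n2)cc1O` has no value yet

Both numbers come from a functional assay on HCT-116 cells (Homo sapiens) for antiproliferative activity, read by MTT assay, with a stated time of 48 h (a higher number here means a weaker inhibitor, a lower number a stronger inhibitor), and compound 2 has the higher of the two (4700 nM), which makes it the weaker inhibitor of the pair. Compound 3 keeps the shared core but carries hydroxy in place of nitro on an aromatic carbon, ortho to a methoxy group (hydroxy in place of nitro on an aromatic carbon).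

Among the measured compounds shown here, only one measured step bears on this change. It puts nitro in place of fluoro on that same carbon, and it is modest but beyond the scatter (a 5.1-fold higher number from compound 1 to compound 2 (0.71 log units; beyond the scatter)). Compound 3 also lacks the nitro group, so a lower number is expected, of roughly that modest size. For the measured compounds named here, no measured compound carries hydroxy, however, so the uncertainty is wide. In this assay the expected step is therefore downward (a 5.9-fold lower number from compound 2 to compound 3 (0.77 log units; beyond the scatter)). Compound 3 is estimated at 800 nM (expected range 180 nM to 3500 nM).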

Compound 3, half-maximal inhibitory concentration: 422 nM
Beside the measured number, compound 3's estimate is 1.9-fold (0.28 log units) above it; low and high end bracket the measured number.
By their numbers in this assay, from the lowest: compound 3; then compound 1; then compound 2.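

In this assay, hydroxy in place of nitro on this aromatic carbon gives an 11-fold lower number from compound 2 to compound 3 (1.05 log units; beyond the scatter) as a large step, so the group at this one position can shift the number well beyond the modest change seen so far. Hydroxy in place of fluoro gives a 2.2-fold lower number from compound 1 to compound 3 (0.34 log units; beyond the scatter) as a modest step, which shows that fluoro does not mark the low end at this carbon, as the first pair alone might have suggested, and places hydroxy lowest of the three groups tried here. Nothing measured here explains why these three groups rank as they do.

As far as these compounds go, three groups on one carbon form only a short series, so it remains open whether an amine, a carboxylic acid or a longer chain joined through oxygen would fall below hydroxy, above nitro or somewhere in between. From the compounds shown here alone, it is also open whether hydroxy would keep its place in this order if the neighbouring methoxy group were replaced by, for example, an ethoxy group.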